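Removing the nitro group from a methyl-bearing pyrazolopyrimidinone

The source may report more compounds than this note shows. Statements on the series, on what has been measured and on what is new or still open speak of the compounds shown alone.

Of the compounds shown here, three sharing one core have been tested in an assay on membranes from brain for binding affinity to adenosine receptor A1 (Rattus norvegicus), read by radioligand binding, tested at 20 uM; a lower number here means less inhibition, a higher number more inhibition at the concentration tested (going by the name of the read-out). Compound 1 `Cn1c(=O)[nH]c2c(cnn2-c2cc(Cl)ccc2Cl)c1=N` gives 1%. Compound 2 `Cn1c(=O)[nH]c2c(cnn2-c2cccc([N+](=O)[O-])c2)c1=N` gives 2%, the second highest of the three numbers, lying within the scatter of compound 1 and far below compound 3. Compound 3 `CCCCn1c(=O)[nH]c2c(cnn2-c2cccc(Cl)c2)c1=N`, which carries a butyl chain and a chloro group instead of the methyl and the nitro group, gives 58%.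

Compound 4 `Cn1c(=O)[nH]c2c(cnn2-c2ccccc2)c1=N` has not yet been measured in this assay. It differs from compound 2 in one place: hydrogen in place of nitro on an aromatic carbon. Within the data shown here, no measured pair shows this exact change, so no step for it is known. The two methyl-bearing compounds, compound 1 and compound 2, both sit at the bottom of the range, and compound 4 keeps the methyl group. The step from compound 2 to compound 4 is therefore expected to be small, a number 6 percentage points higher from compound 2 to compound 4 (within the scatter), with at most a slight rise. Compound 4 is estimated to give 8% in this assay, with a range from 0% to 30%.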

Compound 4, a percentage reported as inhibition, at one concentration (the size of the read-out at that concentration, not a potency): 30%
Estimate against measurement, compound 4: 22 percentage points below, within the range that was stated.
By their numbers in this assay, from the lowest: compounds 1 and 2 (each within the scatter of the next); then compound 4; then compound 3.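

Swapping nitro for hydrogen on this aromatic carbon, meta to a large group, gives a number 28 percentage points higher from compound 2 to compound 4 (beyond the scatter) in this assay. The change at this one place is therefore enough to move the read-out, and keeping the methyl group does not by itself hold a compound at the bottom of the range. No measurement shown gives a reason for this rise.

The compounds shown leave open whether other groups on this carbon, such as an amine or a methoxy group, would also sit above or below the nitro compound. Among these compounds, they also hold no pair that separates the effect of a butyl chain from that of a chloro group, so the contribution of each to the high number of compound 3 stays unknown.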